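Inverting the benzylic stereocentre in the thiourea series

This account rests on a few compounds, and the source may have more. Where it says the series, first, only, none or still open, it means among the compounds named here.

Measured so far:
compound 1, `Cc1nc(N)sc1CCCN/C(N)=N/C(=O)NC(C)c1cccc(F)c1`: 2.04 nM
compound 2, `Cc1nc(N)sc1CCCN/C(N)=N/C(=S)N[C@H](C)c1ccccc1`: 115 nM

In an assay on membranes from Sf9 cells for displacement of a labelled ligand from histamine H2 receptor (Homo sapiens), read by scintillation counting, with a stated time of 60 min (a higher number here means a weaker inhibitor, a lower number a stronger inhibitor), compound 2 gives 115 nM, the highest of the two numbers; compound 1 gives 2.04 nM, a gap well beyond the scatter. Compound 1 and compound 2 differ in more than one place, so the gap is not assigned to either change.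

Compound 3 is `Cc1nc(N)sc1CCCN/C(N)=N/C(=S)N[C@@H](C)c1ccccc1`. Compared with compound 2: the two compounds have the same atoms and bonds and differ only in configuration as drawn: 1 of 2 stereo elements differ; a stereocentre at a saturated chain carbon is drawn R in compound 2 and S in compound 3

Among the measured compounds shown here, no step of this kind is available, so the direction is open; a step beyond the scatter is expected, and compound 3 is estimated at 50 nM (range 6 nM to 400 nM), a step of a 2.3-fold lower number from compound 2 to compound 3 (0.36 log units; beyond the scatter).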

Compound 3, inhibition constant: 339 nM
Compound 3: middle estimate off by 6.8-fold (0.83 log units), on the low side; the range from low to high includes it.
By their numbers in this assay, from the lowest: compound 1; then compound 2; then compound 3.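

In this assay, the stereocentre at the saturated chain carbon matters on its own, with a 2.9-fold higher number from compound 2 to compound 3 (0.47 log units; beyond the scatter). Among the compounds shown here, the R form as drawn in compound 2 is therefore the stronger of this pair, and this gap, unlike the one between compound 1 and compound 2, can be assigned to a single change, because nothing else separates the two: the fact that compounds 2 and 3 differ only in the configuration as drawn.

The step is modest, and it rests on one pair with an unsubstituted phenyl ring. Still open, going by these compounds, is whether the same preference holds with an ethyl group in place of the methyl on that carbon, or with a urea in place of the thiourea.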